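The source may hold more compounds than are shown below. What is called first, only, known or untested is meant among the compounds shown, and "the series" means these compounds.

Compound 1 `O=S(=O)(Nc1nccs1)c1ccc2c(c1)OCC[C@@H]2c1ccc(C(F)(F)F)cc1N1CCNCC1` is the most polar of the three compounds measured in a physicochemical assay for lipophilicity; a higher number here means a more lipophilic compound, a lower number a more polar compound: compound 1 gives 1.4, the lowest of the three numbers. Compound 2 `Cc1ccc(-c2cc(C(F)(F)F)ccc2[C@H]2CCc3cc(S(=O)(=O)Nc4ncccn4)ccc32)cn1` gives 2.8, a number higher than that of compound 1 by more than the usual scatter, and compound 3 `Cc1nc(-c2cc(C(F)(F)F)ccc2[C@@H]2CCOc3cc(S(=O)(=O)Nc4nccs4)ccc32)co1` gives 2.9, the highest of the three and furthest from compound 1, again beyond the scatter. No pair among these three differs in just one place, so no single-change step can be read directly from them.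

Compound 4 `O=S(=O)(Nc1nccs1)c1ccc2c(c1)OCC[C@@H]2c1ccc(C(F)(F)F)cc1-c1ccc(F)cc1` is not yet measured. It departs from compound 1 by 4-fluorophenyl in place of piperazin-1-yl on an aromatic carbon. The piperazin-1-yl group that leaves carries the only hydrogen-bond donor and two acceptors of the exchanged part; the 4-fluorophenyl that enters carries none. Among the measured compounds shown here, compound 1 is the only compound here that bears a piperazin-1-yl group, and compounds 2 and 3, which bear aromatic rings instead, both sit well above it in this assay.

A sizeable upward step is therefore expected, a number 2.40 log units higher from compound 1 to compound 4 (beyond the scatter), clearly beyond the scatter. Compound 4 is estimated at 3.8 in this assay, with a range of 3.2 to 4.4, the upper part of that range resting on compound 3 and its 2.9.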

Compound 4, distribution coefficient: 4.5
Compound 4: the middle estimate sits 0.70 log units below what was measured, outside the stated range (above it).
By their numbers in this assay, from the lowest: compound 1; then compounds 2 and 3 (each within the scatter of the next); then compound 4.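

In this assay, among the compounds shown here, the exchange of piperazin-1-yl for 4-fluorophenyl, on an aromatic carbon ortho to a large group and meta to a trifluoromethyl group, gives a number 3.10 log units higher from compound 1 to compound 4 (beyond the scatter) and is the first single change that can be read directly in this set. With the rest of compound 1 unchanged, the whole of this large step belongs to that one place, where a non-aromatic ring bearing a hydrogen-bond donor and acceptors gives way to a carbon-only aromatic ring bearing neither. Nothing measured here accounts for the size of the step.

The step joins only two end points, so it cannot separate what the departure of piperazin-1-yl contributes from what the arrival of 4-fluorophenyl contributes; a plain phenyl, a piperidin-1-yl or a morpholin-4-yl on the same carbon would be needed to divide it. It also remains open how a carboxylic acid or a short aminoalkyl chain at this position would read, and whether the same exchange gives a step of similar size on the other cores shown.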